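The source may report more compounds than this note shows. Statements on the series, on what has been measured and on what is new or still open speak of the compounds shown alone.

Compound 1 `CS(=O)(=O)Nc1ccc(CNC(=O)c2ccc(C3(C(F)(F)F)CC3)cc2)c(Cl)c1` in an assay on HeLa cells for agonist activity at Bile acid receptor (Homo sapiens), read by a luciferase reporter, with a stated time of 24 h; a lower number here means that less compound is needed, a higher number that more compound is needed for the effect: 540 nM
Compound 2 `CN(C)c1ccc(C(=O)NCc2ccc(NS(C)(=O)=O)cc2Cl)cc1`: 1460 nM

Compound 1 has the lower of these two numbers, and the step of a 2.7-fold higher number from compound 1 to compound 2 (0.43 log units; beyond the scatter) is modest but beyond the scatter. Compound 3 `CC(F)(F)c1ccc(C(=O)NCc2ccc(NS(C)(=O)=O)cc2Cl)cc1` differs from compound 1 by 1,1-difluoroethyl in place of 1-(trifluoromethyl)cyclopropyl on an aromatic carbon. Among the compounds with values here, only one measured step bears on this change, a 2.7-fold higher number from compound 1 to compound 2 (0.43 log units; beyond the scatter), where the same group was exchanged; the entering group here keeps fluorine, so a smaller rise, close to the scatter, is expected. Compound 3 is estimated at 800 nM, between 350 nM and 2000 nM. That estimate means a step of a 1.5-fold higher number from compound 1 to compound 3 (0.17 log units; within the scatter).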

Compound 3, half-maximal effective concentration: 1200 nM
Compound 3: middle estimate off by 1.5-fold (0.18 log units), on the low side, within the range that was stated.
By their numbers in this assay, from the lowest: compound 1; then compounds 3 and 2 (each within the scatter of the next).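

Keeping fluorine at this place on the ring does not preserve the level of compound 1: the change gives a 2.2-fold higher number from compound 1 to compound 3 (0.35 log units; beyond the scatter) and so counts as a real loss. The 1,1-difluoroethyl and dimethylamino groups cannot be told apart, with a 1.2-fold lower number from compound 2 to compound 3 (0.09 log units; within the scatter), so among these three compounds only the 1-(trifluoromethyl)cyclopropyl group stands apart. No measurement offered here accounts for this.

Going by these compounds, it remains open whether the three-membered ring or the fluorine counts for more; a plain cyclopropyl, trifluoromethyl or tert-butyl group at this place would separate the two.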